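The source may report more compounds than this note shows. Statements on the series, on what has been measured and on what is new or still open speak of the compounds shown alone.

Compound 1, `COc1ccc(CNc2nc3cc(N)cc(N)c3nc2-c2ccccc2)cc1OC`, gives 63100 nM in a functional assay on NCI-H522 cells (Homo sapiens) for inhibition, read by sulforhodamine B assay, with a stated time of 48 h; a higher number here means that more compound is tolerated, a lower number that less compound is tolerated.
Compound 3, `COc1ccc(CNc2nc3cc(N)cc(N)c3nc2-c2ccccc2)cc1`, gives 47900 nM in this assay.
Compound 2, `Nc1cc(N)c2nc(-c3ccccc3)c(NCc3ccc(F)cc3)nc2c1`, gives < 100000 nM in this assay; this is a limit of the assay, not a number.

On the numbers shown, compound 2 stands only as a limit, so its place relative to compound 1 and compound 3 cannot be read. The steps a step that the limit leaves unreadable from compound 1 to compound 2 and a step that the limit leaves unreadable from compound 2 to compound 3 are unreadable due to the limit of < 100000 nM in this assay, at which 1 of the 3 values shown sits. Going by the values given here, the one readable step, a 1.3-fold lower number from compound 1 to compound 3 (0.12 log units; within the scatter), is small.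

Compound 4, `Nc1cc(N)c2nc(-c3ccccc3)c(Oc3ccc(F)cc3)nc2c1`, differs from compound 2 by 4-fluorophenoxy in place of (4-fluorobenzyl)amino on an aromatic carbon. Among the compounds with values here, none of the measured steps changes the link between the shared core and the benzyl or phenyl ring; the only readable step touches a substituent on that ring and stays within the scatter. The step from compound 2 to compound 4 is therefore expected to be small, a step that the limit leaves unreadable from compound 2 to compound 4, with no direction claimed beyond the scatter. Compound 4 is expected at about 60000 nM, with a range from 20000 nM to 150000 nM.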

Compound 4, concentration lethal to 50% of the cells: < 100000 nM
Compound 4: a limit, no number; the forecaster's own chance of this, stated with the estimate: 35%; the middle value does not contradict the limit.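

No new step can be read between compound 2 and compound 4, as both stand only as a limit: the limit of < 100000 nM in this assay, at which 2 of the 4 values shown sit. As far as these compounds go, what stays open is whether 4-fluorophenoxy and (4-fluorobenzyl)amino differ at all in this assay, and where compound 2 and compound 4 stand relative to compound 1 and compound 3.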